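Shortening the Ester Side Chain of a Weak Inhibitor

The source may report more compounds than this note shows. Statements on the series, on what has been measured and on what is new or still open speak of the compounds shown alone.

Compound 1 `COc1ccc(C(=O)Nc2cccc(Cl)c2Cl)cc1OC1CCCC1`: in an assay on isolated protein for inhibition of phosphodiesterase 4A (Sus scrofa) (a higher number here means a weaker inhibitor, a lower number a stronger inhibitor), compound 1 gives > 200000 nM, which is a limit of the assay and not a number.
Compound 2 `COc1ccc(C(=O)Nc2ccccc2Cl)cc1OC(=O)C1CCCC1`: in this assay compound 2 gives > 1000000 nM, likewise a limit of the assay rather than a number.

Neither measured compound yields an actual inhibitory concentration. Compound 2 sits at the limit of > 1000000 nM in this assay, at which 1 of the 2 values shown sits, the higher of the two limits seen here. Compound 1 sits at the limit of > 200000 nM in this assay, at which 1 of the 2 values shown sits. For the measured compounds named here, the two compounds differ in more than one place, so no single step connects them; all that can be said is that both fall outside the measurable range.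

Compound 3 `COc1ccc(C(=O)Nc2ccccc2Cl)cc1OC(C)=O` differs from compound 2 in one place: methyl in place of cyclopentyl on a carbonyl carbon. Going by the values given here, no measured step is available to show how much such a change matters here. Since compound 2 sits at the limit of > 1000000 nM in this assay, at which 1 of the 2 values shown sits, there is no measured potency from which a shift could be read, and the expectation is that compound 3 will again return only a limit. The step from compound 2 to compound 3 is therefore estimated as a number no higher from compound 2 to compound 3 (the limit leaves the size open), essentially no change beyond the scatter. Compound 3 is expected to give 1000000 nM, within 100000 nM to 10000000 nM.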

Compound 3, half-maximal inhibitory concentration: 70000 nM
Estimate against measurement, compound 3: 14-fold (1.15 log units) above, and the stated range ends above it.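

In this assay, replacing cyclopentyl with methyl on a carbonyl carbon gives an at least 14-fold lower number from compound 2 to compound 3 (1.15 log units; beyond the scatter), which shows that the group at this place can decide whether an inhibitory concentration can be read at all. For the compounds shown here, compound 3 gives 70000 nM, the first actual number in this set, though it is still a high one for an inhibitor, and it provides a measured point against which further changes at this place can be compared. The true size of the step stays open, because compound 2 stands at a limit of the assay and not at a number: the limit of > 1000000 nM in this assay, at which 1 of the 3 values shown sits.

With only cyclopentyl and methyl compared at this carbonyl carbon, the pair cannot say whether the gain depends on removing the ring or on shortening the group in general, nor how the potency would change along a path from one to the other. An ethyl, an isopropyl or a cyclopropyl group at the same place could help separate these possibilities, while a longer chain ending in an amine or a carboxylic acid would test whether this place accepts anything beyond plain carbon groups.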